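From cyclohexyl to 4-chloropyridin-2-yl: compound 3

The compounds below may be only part of what the source reports. "The series", "measured", "known", "first", "only" and "open" are said of these compounds alone.

Values in a functional assay on MDA-MB-231 cells (Homo sapiens) for inhibition, read by CCK-8 assay, with a stated time of 48 h; a higher number here means a weaker inhibitor of growth, a lower number a stronger inhibitor of growth:
compound 1 `Cc1ccccc1Nc1nc(Nc2cccnc2)ncc1Cl`: 41200 nM
compound 2 `Cc1ccccc1Nc1nc(NC2CCCCC2)ncc1Cl`: > 100000 nM (a limit)

In this assay compound 2 gives > 100000 nM, which is a limit of the assay and not a number. Compound 2 therefore has no measured position in the series.

Compound 3 `Cc1ccccc1Nc1nc(Nc2cc(Cl)ccn2)ncc1Cl` shares its core with compound 2 and differs in one place: 4-chloropyridin-2-yl in place of cyclohexyl on a nitrogen on an aromatic ring. This puts 4-chloropyridin-2-yl in place of cyclohexyl on a nitrogen on an aromatic ring.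

Among the measured compounds shown here, one measured step bears on this change: cyclohexyl in place of pyridin-3-yl gave an at least 2.4-fold higher number from compound 1 to compound 2 (0.38 log units; beyond the scatter), which lies beyond the scatter. Compound 3 restores a pyridine-based group, so that step is read in reverse, and a move to a lower number is expected, of at least modest size. The chlorine and the changed point of attachment are not covered by any measured step. Compound 1, at 41200 nM, is the nearest guide.

The expected change is an at least 2.8-fold lower number from compound 2 to compound 3 (0.45 log units; beyond the scatter). For compound 3 the estimated value is 35000 nM, with an expected range of 10000 nM to 100000 nM.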

Compound 3, concentration for 50% growth inhibition: 52400 nM
For compound 3 the middle estimate is 1.5-fold (0.18 log units) below the measured one; measured number inside the range.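

In this assay, 4-chloropyridin-2-yl in place of cyclohexyl gives an at least 1.9-fold lower number from compound 2 to compound 3 (0.28 log units; that floor lies within the scatter), so this change on its own does not establish a gain beyond the scatter. That step remains only a floor because compound 2 carries a limit and not a number: the limit of > 100000 nM in this assay, at which 1 of the 3 values shown sits.

The more informative comparison is 4-chloropyridin-2-yl in place of pyridin-3-yl, which gives a 1.3-fold higher number from compound 1 to compound 3 (0.10 log units; within the scatter), so the two pyridine-based groups on this nitrogen cannot be told apart in this read-out, despite the added chlorine and the changed point of attachment.

The chlorine and the point of attachment change together between these two groups, and the compounds shown do not separate their contributions. Also open, going by these compounds, is how a plain pyridin-2-yl, a phenyl or a 4-methoxypyridin-2-yl on this nitrogen would read, and whether any such group would move the number beyond the scatter of the two pyridine-based compounds.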